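Solubility notes on the furfurylamine quinoline series

A few compounds are considered here, and "the series" means these few. Any claim that something is new, unique, unknown or untested is made for them only; others in the source may bear on it.

Measured so far:
compound 1 `Cc1cc(C)cc(Cc2ccc3c(NCCCNCc4ccco4)ccnc3c2)c1` gives 4200 nM in a physicochemical assay for solubility, with a stated time of 18 h, at pH 7.4; on this read-out lower numbers stand for lower solubility and higher numbers for higher solubility
compound 2 `COc1ccccc1Oc1ccc2c(NCCCNCc3ccco3)ccnc2c1` gives 14500 nM in this assay

Within the data shown here, compound 2 holds the higher of the two numbers in this assay; the only neighbour is compound 1, and the gap from compound 1 to compound 2 is a 3.5-fold higher number from compound 1 to compound 2 (0.54 log units; beyond the scatter), a modest but real step that goes with 2-methoxyphenoxy in place of 3,5-dimethylbenzyl on an aromatic carbon of the shared core.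

The next compound, compound 3 `COc1ccc(-c2ccc3c(NCCCNCc4ccco4)ccnc3c2)cc1`, differs from compound 2 in one place: 4-methoxyphenyl in place of 2-methoxyphenoxy on an aromatic carbon. Among the measured compounds shown here, no measured step touches exactly this exchange. For the measured compounds named here, the one step on record, from compound 1 to compound 2, concerns the same attachment point and shows that a change of the group there moves this assay by a modest amount; it says nothing direct about replacing the aryl ether by a directly linked aryl. On that basis a step of similar magnitude is expected, most plausibly a decrease from compound 2, with the estimated step from compound 2 to compound 3 being a 2.1-fold lower number from compound 2 to compound 3 (0.32 log units; beyond the scatter). Compound 3 is therefore expected to give about 7000 nM in this assay, within a range from 2500 nM to 22000 nM.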

Compound 3, solubility: 32000 nM
Estimate against measurement, compound 3: 4.6-fold (0.66 log units) below; the measured number lies above the stated range.
By their numbers in this assay, from the lowest: compound 1; then compound 2; then compound 3.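

At this aromatic carbon, 4-methoxyphenyl gives the highest number of the three groups in this assay, and the directly attached aryl stands clearly above both the aryl ether (a 2.2-fold higher number from compound 2 to compound 3 (0.34 log units; beyond the scatter)) and the benzyl group (a 7.6-fold higher number from compound 1 to compound 3 (0.88 log units; beyond the scatter)). Among these compounds, the earlier pair showed only that the number moves with the group at this carbon, whereas the new compound shows that a large part of the range is reached among groups that each carry a single six-membered aromatic ring of carbon only, so that ring alone does not fix the number. The hydrogen-bond acceptor count also gives no simple guide within this exchange, as 4-methoxyphenyl has one acceptor fewer than 2-methoxyphenoxy yet gives the higher number, and no measurement on hand explains the rise.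

Going by these compounds, the exchange removes the ether link and shifts the methoxy group in one move, so the share of each in the step remains open. Also open, on these data alone, is how this position reads with a plain phenyl, a 2-methoxyphenyl, or a group carrying an amine or a carboxylic acid, any of which would test whether the present order holds.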